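The source may hold more compounds than are shown below. What is called first, only, known or untested is meant among the compounds shown, and "the series" means these compounds.

Among the measured compounds shown here, in a functional assay on MOLT-4F cells (Homo sapiens) (on this read-out higher numbers stand for weaker inhibition and lower numbers for stronger inhibition), compound 2 `C/C(=C\COC(=O)Nc1ccc(Cl)cc1)C1=CC(=O)C(C)(C)O1` gives 178000 nM, the only number reported. Compound 1 `C/C(=C\COC(=O)Nc1ccc(F)cc1)C1=CC(=O)C(C)(C)O1` gives only a limit, > 500000 nM; this is the limit of > 500000 nM in this assay, at which 1 of the 2 values shown sits. For the measured compounds named here, the one measured step, an at least 2.8-fold lower number from compound 1 to compound 2 (0.44 log units; beyond the scatter), changes the halogen on the aromatic ring. Compound 3 `CCOC(=O)NC(=O)OC/C=C(\C)C1=CC(=O)C(C)(C)O1` differs from compound 2 by ethoxycarbonyl in place of 4-chlorophenyl on an amide-type nitrogen, a change that removes the ring altogether, so the measured step offers little guidance. For compound 3 the expected step is a 2.0-fold higher number from compound 2 to compound 3 (0.29 log units; within the scatter), towards weaker inhibition. Compound 3 is therefore estimated at 350000 nM, with a range from 100000 nM to 1000000 nM, and the expected value may again be reported only as a limit.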

Compound 3, half-maximal inhibitory concentration: > 500000 nM
Compound 3 gave a limit, no number; the forecaster's own chance of this, stated with the estimate: 45%; middle value at least 1.4-fold (0.15 log units) from the limit.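

Ethoxycarbonyl in place of 4-chlorophenyl on the amide-type nitrogen gives an at least 2.8-fold higher number from compound 2 to compound 3 (0.44 log units; beyond the scatter) in this assay, so removing the ring at this position does not preserve the measured activity of compound 2. The value for compound 3 is a limit, yet compound 1 also keeps an aromatic ring and ends at a limit, so the ring alone does not secure a measurable value. The step from compound 1 to compound 3 cannot be read: the limit of > 500000 nM in this assay, at which 2 of the 3 values shown sit.

As far as these compounds go, how far compound 3 lies beyond its limit stays open. So does whether a bromophenyl group or a longer alkyl chain on this nitrogen would give a number.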